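The source may report more compounds than this note shows. Statements on the series, on what has been measured and on what is new or still open speak of the compounds shown alone.

Measured compounds:
compound 1 `CC[C@](C)(O)CC(=O)O[C@H](CC=C(C)C)C1=CC(=O)c2c(O)ccc(O)c2C1=O` — 20500 nM
compound 2 `CCCCCCC(C)(O)CC(=O)O[C@H](CC=C(C)C)C1=CC(=O)c2c(O)ccc(O)c2C1=O` — a limit of the assay, > 100000 nM

In a functional assay on DU-145 cells (Homo sapiens) for cytotoxicity, read by MTT assay (on this read-out lower numbers stand for stronger inhibition and higher numbers for weaker inhibition), compound 1 holds the only number shown, the other value being a limit. Compound 2 sits at the limit (the limit of > 100000 nM in this assay, at which 1 of the 2 values shown sits), so the step of an at least 4.8-fold higher number from compound 1 to compound 2 (0.68 log units; beyond the scatter) can only be read as a floor on how much weaker compound 2 is.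

Compound 3 `CC(C)=CC[C@@H](OCCO)C1=CC(=O)c2c(O)ccc(O)c2C1=O` differs from compound 1 by 2-hydroxyethyl in place of (2-hydroxy-2-methylbutyl)carbonyl on an oxygen on a saturated carbon. No measured step removes the (2-hydroxy-2-methylbutyl)carbonyl in this way; the one step shown, an at least 4.8-fold higher number from compound 1 to compound 2 (0.68 log units; beyond the scatter), lengthens the chain on that group instead, so it bears only loosely on compound 3. Within the data shown here, with compound 1 already weak and no direct precedent, the step of a 1.5-fold higher number from compound 1 to compound 3 (0.17 log units; within the scatter) is expected to stay near the scatter, with a wide spread. Compound 3 is therefore estimated at 30000 nM, within a range of 8000 nM to 100000 nM.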

Compound 3, half-maximal inhibitory concentration: 9900 nM
For compound 3 the middle estimate is 3.0-fold (0.48 log units) above the measured one; the range from low to high includes it.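

Compound 2 had shown only that lengthening the chain on the (2-hydroxy-2-methylbutyl)carbonyl can cost activity. Compound 3 shows that this whole group can leave the oxygen on a saturated carbon without a loss: in this assay, putting 2-hydroxyethyl in its place gives a 2.1-fold lower number from compound 1 to compound 3 (0.32 log units; beyond the scatter), a modest gain that lies beyond the usual scatter, so the carbonyl group is not required for this level of activity. Nothing shown here explains why the number falls with this change.

This single swap changes the carbonyl and the chain length together, so the compounds shown cannot say which of these matters. On these data alone, a longer chain ending in a hydroxyl, or an amine in place of that hydroxyl on the 2-hydroxyethyl, remains open, as does whether activity can improve much further from this still weak level.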